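Hydroxyphenyl-substituted series: replacement of pyridin-2-yl by phenyl

The compounds below may be only part of what the source reports. "The series", "measured", "known", "first", "only" and "open" are said of these compounds alone.

Measured compounds:
compound 1 `Oc1ccc(-c2cc(-c3cccc(Cl)c3)nc(-c3ccccn3)c2)cc1` — 27900 nM
compound 2 `Oc1cccc(-c2cc(-c3cccc(Cl)c3)nc(-c3ccccn3)c2)c1` — "not determined" (no result reported)

Compound 1 `Oc1ccc(-c2cc(-c3cccc(Cl)c3)nc(-c3ccccn3)c2)cc1` is a weak inhibitor in a functional assay on T47D cells (Homo sapiens) for cytotoxicity, read by CCK-8 assay and cell counting, with a stated time of 2 days (a higher number here means a weaker inhibitor, a lower number a stronger inhibitor), giving 27900 nM. Compound 2 `Oc1cccc(-c2cc(-c3cccc(Cl)c3)nc(-c3ccccn3)c2)c1` shares the core of compound 1 and differs only in where the hydroxy group sits on its phenyl ring; for compound 2 the result in this assay is "not determined" (no result reported), so its standing cannot be placed against compound 1.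

Compound 3 `Oc1cccc(-c2cc(-c3ccccc3)nc(-c3cccc(Cl)c3)c2)c1` is the next member to be tested. It differs from compound 2 as follows: phenyl in place of pyridin-2-yl on an aromatic carbon

Among the compounds with values here, no step between measured compounds is available, so the direction of this change cannot be read from the series. Given only the weak result for compound 1, the expectation for compound 3 in this assay is a step of no more than the usual scatter in either direction, with the compound remaining a weak inhibitor. Compound 3 is estimated at 30000 nM, in the range 8000 nM to 100000 nM.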

Compound 3, half-maximal inhibitory concentration: 3700 nM
Beside the measured number, compound 3's estimate is 8.1-fold (0.91 log units) above it, outside the stated range (below it).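

No new step can be read: compound 2 has no single number, so the change from pyridin-2-yl to phenyl in compound 3 has no value to be compared against. The compounds shown leave open what that change does to potency, and whether hydroxy position matters. Nothing available bears on a cause for this result.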